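Stripping the Bromines from a Cytotoxic Dibromophenyl Analogue

This account rests on a few compounds, and the source may have more. Where it says the series, first, only, none or still open, it means among the compounds named here.

Compound 3 `Cn1c(=O)c(-c2c(Br)cccc2Br)cc2c(N)nc(Nc3ccccc3)nc21` gives 800 nM in an ADME assay on Huh-7 cells (Homo sapiens) for cytotoxicity, read by MTT assay, with a stated time of 4 h, at 37 degrees C (a lower number here means that less compound is tolerated, a higher number that more compound is tolerated), the lowest of the three numbers recorded there. Its nearest neighbour is compound 2 `Cn1c(=O)c(-c2c(F)cccc2F)cc2c(N)nc(Nc3ccccc3)nc21`, which gives 10400 nM, and the furthest is compound 1 `O=C1Nc2nc(NCc3ccccc3)[nH]c(=O)c2CC1c1c(Cl)cccc1Cl`, which gives 69000 nM. For the measured compounds named here, the one step between two measured compounds that differ in a single place is a 13-fold lower number from compound 2 to compound 3 (1.11 log units; beyond the scatter); putting 2,6-dibromophenyl in place of 2,6-difluorophenyl on an aromatic carbon was therefore felt strongly in this assay.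

Compound 4 `Cn1c(=O)c(-c2ccccc2)cc2c(N)nc(Nc3ccccc3)nc21` is obtained from compound 3 by the change (phenyl in place of 2,6-dibromophenyl on an aromatic carbon). The step from compound 2 to compound 3 bears directly on it: both steps touch only the ring attached at that aromatic carbon, and in the one measured case the 2,6-dibromophenyl brought the lower number. Going by the values given here, removing both bromines altogether points the other way, so a large rise is expected, back toward the region of compound 2 and possibly past it, though a bare phenyl has no measured counterpart here and the size of the rise is uncertain. Compound 4 is therefore expected to give 8000 nM (range 2000 nM to 30000 nM), which would mean a 10-fold higher number from compound 3 to compound 4 (1.00 log units; beyond the scatter).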

Compound 4, half-maximal cytotoxic concentration: 23500 nM
Compound 4: middle estimate off by 2.9-fold (0.47 log units), on the low side; measured number inside the range.
By their numbers in this assay, from the lowest: compound 3; then compound 2; then compound 4; then compound 1.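

Set against the bare phenyl, the two halogenated rings at this aromatic carbon no longer look like a simple contrast between compounds 2 and 3. In this assay, removing both bromines gives a large change (a 29-fold higher number from compound 3 to compound 4 (1.47 log units; beyond the scatter)), whereas removing both fluorines gives only a modest one (a 2.3-fold higher number from compound 2 to compound 4 (0.35 log units; beyond the scatter)), so most of the spread among these three compounds lies on the side of the 2,6-dibromophenyl ring. Both steps lie beyond the scatter and run in the same direction, giving an order across this small series, on the shared core, from phenyl through 2,6-difluorophenyl to 2,6-dibromophenyl, but nothing presented accounts for that order or for the unequal sizes of the steps.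

The compounds shown leave open whether a single halogen, as in 2-bromophenyl, would lie nearer the phenyl or the 2,6-dibromophenyl end, and whether a 2,6-dimethylphenyl ring, which carries no halogen, would also give a lower number than the phenyl. For the compounds shown here, they also leave open whether the same replacement would have a comparable effect on the different core of compound 1, since its ring at the corresponding place has no phenyl counterpart here.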